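The source may hold more compounds than are shown below. What is called first, only, known or untested is meant among the compounds shown, and "the series" means these compounds.

The compounds share one core and differ only in the group on the amide-type nitrogen. In a functional assay on MCF7 cells (Homo sapiens) for antiproliferative activity, read by MTT assay, with a stated time of 24 h (on this read-out lower numbers stand for stronger inhibition and higher numbers for weaker inhibition), compound 3, `CCn1c(C(=O)N[C@H](CO)CCO)ccc1C(CC)(CC)c1ccc(OCS(=O)(=O)c2ccccc2)c(C)c1`, gives 28500 nM, the lowest of the two numbers shown. Its nearest neighbour is compound 2, `CCn1c(C(=O)NCCCO)ccc1C(CC)(CC)c1ccc(OCS(=O)(=O)c2ccccc2)c(C)c1`, which in this assay gives 42000 nM; the step of a 1.5-fold lower number from compound 2 to compound 3 (0.17 log units; within the scatter) sits within the scatter. Compound 1, `CCn1c(C(=O)NCCNC(=O)OC(C)(C)C)ccc1C(CC)(CC)c1ccc(OCS(=O)(=O)c2ccccc2)c(C)c1`, reaches only a limit of this assay, > 50000 nM, which is a limit of the assay and not a number (the limit of > 50000 nM in this assay, at which 1 of the 3 values shown sits). From it the steps of an at least 1.1-fold lower number from compound 1 to compound 2 (0.07 log units; that floor lies within the scatter) and an at least 1.7-fold lower number from compound 1 to compound 3 (0.24 log units; that floor lies within the scatter) are floors that also lie within the scatter.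

Compound 4, `CCn1c(C(=O)N[C@@H](C(=O)O)C(C)C)ccc1C(CC)(CC)c1ccc(OCS(=O)(=O)c2ccccc2)c(C)c1`, has not been measured. It differs from compound 3 in one place: 1-carboxy-2-methylpropyl in place of 3-hydroxy-1-(hydroxymethyl)propyl on an amide-type nitrogen. Every measured step here alters this same group on the amide-type nitrogen, and none of them moved the number beyond the scatter. On that basis the expectation for compound 4 is a step of a 1.2-fold higher number from compound 3 to compound 4 (0.09 log units; within the scatter), that is, nothing beyond the usual scatter, while the limit seen for compound 1 leaves room for a weaker result. The estimate for compound 4 in this assay is therefore 35000 nM, with a range from 12000 nM to 100000 nM.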

Compound 4, half-maximal inhibitory concentration: 44700 nM
Beside the measured number, compound 4's estimate is 1.3-fold (0.11 log units) below it, and the stated range covers the measured number.
By their numbers in this assay, from the lowest: compounds 3, 2 and 4 (each within the scatter of the next). At a limit, above all of these: compound 1.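

Compound 4 brings a carboxy group onto the amide-type nitrogen, a kind of group absent from compounds 1 to 3, which end in hydroxyl or (tert-butoxycarbonyl)amino groups, and in this assay both a 1.6-fold higher number from compound 3 to compound 4 (0.20 log units; within the scatter) and a 1.1-fold higher number from compound 2 to compound 4 (0.03 log units; within the scatter) remain within the scatter. This position therefore now carries a branched 1-carboxy-2-methylpropyl group as well as the hydroxyl-bearing chains, and no step among these three compounds can be told from the scatter. Compound 1 remains at a limit and not a number, so an at least 1.1-fold lower number from compound 1 to compound 4 (0.04 log units; that floor lies within the scatter) is only a floor and gives no size for that change: the limit of > 50000 nM in this assay, at which 1 of the 4 values shown sits.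

Because the step from compound 3 to compound 4 changes the whole group at once, the compounds shown do not separate the part played by the carboxylic acid from that of the branched isopropyl end. From the compounds shown here alone, it also remains open whether a free primary amine, a longer chain ending in a carboxylic acid, or a methyl ester of the acid on this nitrogen would move the number clearly beyond the scatter.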